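Fluoro substitution in a beta-amino acid series

This account rests on a few compounds, and the source may have more. Where it says the series, first, only, none or still open, it means among the compounds named here.

Measured compounds:
compound 1 `O=C(O)CC(NC(=O)c1ccc(Cl)cc1Cl)c1ccccc1`: 67200 nM in a functional assay on MDA-MB-231 cells (Homo sapiens) for antiproliferative activity, read by MTT assay, with a stated time of 24 h; a lower number here means a stronger inhibitor, a higher number a weaker inhibitor
compound 2 `CC(C)(C)c1ccc(C(CC(=O)O)NS(=O)(=O)c2ccccc2)cc1`: a limit only, > 100000 nM in this assay
compound 3 `CC(C)(C)c1ccc(C(CC(=O)O)NS(=O)(=O)c2ccc(F)cc2)cc1`: 66200 nM in this assay

Compound 2 gives no number in this assay, only a limit; this is the limit of > 100000 nM in this assay, at which 1 of the 3 values shown sits. Compound 3 carries fluoro in place of hydrogen on an aromatic carbon relative to compound 2 and shows an at least 1.5-fold lower number from compound 2 to compound 3 (0.17 log units; that floor lies within the scatter). How the core of compound 1 differs from that of compound 2 is not broken down here. Compound 1 and compound 3 give values within the scatter of each other in this assay.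

Compound 4 `O=C(O)CC(NC(=O)c1ccc(Cl)cc1Cl)c1ccccc1F` is not yet measured. It carries fluoro in place of hydrogen on an aromatic carbon. This is the same kind of change as from compound 2 to compound 3, but not the same: there the fluoro sits para to a large group, here ortho to a large group.

For compound 4 in this assay a step of a 1.3-fold lower number from compound 1 to compound 4 (0.13 log units; within the scatter) is expected, resting on compound 1 at 67200 nM and on the earlier step of an at least 1.5-fold lower number from compound 2 to compound 3 (0.17 log units; that floor lies within the scatter). The estimate for compound 4 is 50000 nM, expected to fall between 25000 nM and 100000 nM.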

Compound 4, half-maximal inhibitory concentration: 89300 nM
For compound 4 the middle estimate is 1.8-fold (0.25 log units) below the measured one; measured number inside the range.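

In this assay, fluoro in place of hydrogen on the core of compound 1 (phenyl to 2-fluorophenyl) gives a 1.3-fold higher number from compound 1 to compound 4 (0.12 log units; within the scatter), so on this core the change stays within the scatter. The two steps support neither a shared effect of the change across cores nor a dependence on the core, and they also place the fluoro differently: the same change on two cores in this assay, an at least 1.5-fold lower number (0.17 log units; that floor lies within the scatter) from compound 2 to compound 3 and a 1.3-fold higher number (0.12 log units; within the scatter) from compound 1 to compound 4; the limit leaves it open whether they differ. The value of compound 2 is a limit and not a number: the limit of > 100000 nM in this assay, at which 1 of the 4 values shown sits.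

Open, from the compounds shown here alone, is whether fluoro elsewhere on the phenyl ring of the core of compound 1 would give a step beyond the scatter, and whether a larger replacement for that hydrogen, such as methoxy or trifluoromethyl, would do so. Also open, going by these compounds, is how either core responds when the carboxylic acid is replaced by a primary amide or a methyl ester.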